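Swapping Chloro for Methyl on a Thiosemicarbazone-Type Series

The source may report more compounds than this note shows. Statements on the series, on what has been measured and on what is new or still open speak of the compounds shown alone.

Among the measured compounds shown here, in a functional assay on UACC-62 cells (Homo sapiens) for inhibition, read by sulforhodamine B assay, with a stated time of 48 h (on this read-out higher numbers stand for weaker inhibition of growth and lower numbers for stronger inhibition of growth), compound 1 `S=C(N/N=C/c1cccs1)Nc1ccc(Cl)cc1` gives 15800 nM, the only true number so far. Compound 2 `S=C(N/N=C/c1cccs1)Nc1cccnc1` reads > 100000 nM, which is a limit of the assay and not a number. Compound 3 `Cc1ccc(NC(=S)N/N=C/c2cccs2)cc1` remains to be measured. It keeps the core of compound 1 and changes one group: methyl in place of chloro on an aromatic carbon, para to a large group. For the measured compounds named here, no measured pair shows this change, so the expectation rests on compound 1 at 15800 nM alone. A small step towards weaker inhibition of growth in this assay is expected, hardly beyond the usual scatter, and the estimated step is a 1.6-fold higher number from compound 1 to compound 3 (0.20 log units; within the scatter). For compound 3 the expected value is 25000 nM, with an estimated range from 9000 nM to 70000 nM.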

Compound 3, concentration for 50% growth inhibition: 16800 nM
For compound 3 the middle estimate is 1.5-fold (0.17 log units) above the measured one; measured number inside the range.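

Among the compounds shown here, the first measured pair for this change gives a 1.1-fold higher number from compound 1 to compound 3 (0.03 log units; within the scatter) in this assay. Before this pair, the value of compound 1 stood alone, with nothing to show what a change at this place would do; now, on an aromatic carbon para to a large group, chloro and methyl cannot be told apart in this read-out, and the shared core carries either group with the same reading within the scatter. Nothing among the data shown gives a cause for this result.

Going by these compounds, whether an amine, a methoxy group or a carboxylic acid at the same place would also leave the reading where it is stays open. On these data alone, whether methyl and chloro remain interchangeable at any other place on this ring, or on a different core, also stays open.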